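This account rests on a few compounds, and the source may have more. Where it says the series, first, only, none or still open, it means among the compounds named here.

Measured compounds:
- compound 1, `COc1cc(Cl)cc(-c2nn(-c3cccc(NC(=O)Nc4ccc(Cl)c(C(F)(F)F)c4)c3)cc2-c2ccncc2)c1`, 450 nM
- compound 2, `COc1cc(Cl)cc(-c2nn(-c3cccc(NC(=O)Nc4cc(C(F)(F)F)cc(C(F)(F)F)c4)c3)cc2-c2ccncc2)c1`, 330 nM
- compound 3, `COc1cc(Cl)cc(-c2nn(-c3cccc(NC(=O)Nc4ccc(Cl)c(Cl)c4)c3)cc2-c2ccncc2)c1`, 1560 nM

In a functional assay on OVCAR-3 cells (Homo sapiens) for inhibition, read by sulforhodamine B assay, with a stated time of 48 h (on this read-out higher numbers stand for weaker inhibition and lower numbers for stronger inhibition), compound 3 gives the highest number of the three, with compound 1 the nearest and compound 2 the furthest. Compound 4, `COc1cc(Cl)cc(-c2nn(-c3cccc(NC(=O)Nc4cccc(C(F)(F)F)c4)c3)cc2-c2ccncc2)c1`, has not yet been measured; it differs from compound 3 by 3-(trifluoromethyl)phenyl in place of 3,4-dichlorophenyl on an amide-type nitrogen. For the measured compounds named here, one measured step bears on this change: a 3.5-fold higher number from compound 1 to compound 3 (0.54 log units; beyond the scatter), the same swap of chloro for trifluoromethyl in the opposite direction. Going by the values given here, compound 4 also loses the second chloro, a change no measured pair shows. A modest step in this assay toward a lower number is therefore expected, a 3.1-fold lower number from compound 3 to compound 4 (0.49 log units; beyond the scatter). Compound 4 is estimated at 500 nM, within a range of 200 nM to 1500 nM.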

Compound 4, half-maximal inhibitory concentration: 590 nM
Compound 4: the middle estimate sits 1.2-fold (0.07 log units) below what was measured; measured number inside the range.
By their numbers in this assay, from the lowest: compounds 2, 1 and 4 (each within the scatter of the next); then compound 3.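

In this assay, 3-(trifluoromethyl)phenyl on the amide-type nitrogen does better than 3,4-dichlorophenyl, giving a 2.6-fold lower number from compound 3 to compound 4 (0.42 log units; beyond the scatter). Hydrogen in place of the chloro gives a 1.3-fold higher number from compound 1 to compound 4 (0.12 log units; within the scatter), and hydrogen in place of the second trifluoromethyl gives a 1.8-fold higher number from compound 2 to compound 4 (0.25 log units; within the scatter); both steps lie within the scatter, so neither extra group has a visible effect on top of the single trifluoromethyl. Nothing shown here explains these differences. As far as these compounds go, whether a methyl or a nitrile could replace that trifluoromethyl stays open. So does the effect of a morpholine or a carboxylic acid on this ring.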